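Chloro to Fluoro on a Limit-Bound Aryl Ether

A few compounds are considered here, and "the series" means these few. Any claim that something is new, unique, unknown or untested is made for them only; others in the source may bear on it.

All compounds were examined in an assay on isolated protein for inhibition of Amine oxidase [flavin-containing] A (Homo sapiens), read by fluorescence, with a stated time of 15 min; on this read-out higher numbers stand for weaker inhibition and lower numbers for stronger inhibition. Compound 1 `O=C1CCc2ccc(OCc3cccc(Cl)c3)cc2N1` gives only a limit, > 100000 nM. Compound 2 `CC(=O)c1ccc(OCc2cccc(Cl)c2)cc1F` likewise gives only a limit, > 100000 nM. Compound 3 `O=c1ccoc2cc(OCc3ccc(C(F)(F)F)cc3)ccc12` gives a number, 18900 nM. Compound 2 therefore stands at the limit of > 100000 nM in this assay, at which 2 of the 3 values shown sit, without a number of its own. Compound 4 `CC(=O)c1ccc(OCc2cccc(F)c2)cc1F` has not yet been measured in this assay; it differs from compound 2 by fluoro in place of chloro on an aromatic carbon. For the measured compounds named here, no step between measured compounds is available, so the size of such a change cannot be read from this set. Because compound 2 sits at the limit of > 100000 nM in this assay, at which 2 of the 3 values shown sit, compound 4 is expected to remain within the scatter of it, with the step that the limit leaves unreadable from compound 2 to compound 4 amounting to nothing beyond that. Compound 4 is accordingly estimated at 120000 nM, in the range 30000 nM to 500000 nM.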

Compound 4, half-maximal inhibitory concentration: > 100000 nM
Compound 4 was reported as a limit; the forecaster's own chance of this, stated with the estimate: 85%; the middle value does not contradict the limit.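

Compound 2 and compound 4 each give only a limit in this assay, so no step can be read between them. The compounds shown leave open whether fluoro in place of chloro changes inhibition at all.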